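Swapping the Carbamate Cap for an Oxadiazole Ring

A few compounds are considered here, and "the series" means these few. Any claim that something is new, unique, unknown or untested is made for them only; others in the source may bear on it.

Within the data shown here, compound 1 `COCCOC(=O)N1CCC(Oc2ncnc3c2CCN3c2ccc(S(C)(=O)=O)cc2F)CC1` is one of two compounds so far measured in a functional assay on CHO-K1 cells for agonist activity at Glucose-dependent insulinotropic receptor (Homo sapiens), read by a luciferase reporter, with a stated time of 5 h; a higher number here means that more compound is needed for the effect, a lower number that less compound is needed. Compound 1 gives 316 nM, which is the higher of the two numbers. Compound 2 `CC(C)c1noc(N2CCC(O)CC2)n1` is a much smaller molecule and differs from compound 1 in more than one place, so only its value can be set beside that of compound 1: compound 2 gives 50.1 nM in this assay, and the two values lie apart by more than the usual scatter, meaning that less of compound 2 is needed than of compound 1. Compound 3 `CC(C)c1noc(N2CCC(Oc3ncnc4c3CCN4c3ccc(S(C)(=O)=O)cc3F)CC2)n1` has not yet been measured. It keeps the core of compound 1 and changes one part: 3-isopropyl-1,2,4-oxadiazol-5-yl in place of (2-methoxyethoxy)carbonyl on an amine nitrogen in a ring. The group that enters is the same ring that compound 2 carries. Among the measured compounds shown here, because compound 2 reaches 50.1 nM carrying only that ring, the change is expected to lower the number for compound 3, although with only two measured compounds the size of the step is uncertain. The step of a 5.3-fold lower number from compound 1 to compound 3 (0.72 log units; beyond the scatter) is estimated to run beyond the scatter. For compound 3 a value of 60 nM is expected, with a range from 15 nM to 250 nM.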

Compound 3, half-maximal effective concentration: 79.4 nM
Compound 3: the middle estimate sits 1.3-fold (0.12 log units) below what was measured, within the range that was stated.
By their numbers in this assay, from the lowest: compounds 2 and 3 (each within the scatter of the next); then compound 1.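

In this assay, the cap on the amine nitrogen of the six-membered ring proves to be a place where a change registers: with the core of compound 1 held fixed, 3-isopropyl-1,2,4-oxadiazol-5-yl in place of (2-methoxyethoxy)carbonyl gives a 4.0-fold lower number from compound 1 to compound 3 (0.60 log units; beyond the scatter) and so a modest step that still clears the usual scatter. The two groups have the same counts of hydrogen-bond donors and acceptors and neither has a net charge, so these counts do not tell them apart; the clear difference is that the entering group is a five-membered aromatic ring, whereas the leaving group has no ring. No measurement offered here bears on why the number falls, so the step stands as an observation only.

The compounds shown leave open whether the step belongs to the aromatic ring or to the isopropyl group it carries, a question that a methyl or a cyclopropyl group on the same ring could help settle. They also leave open whether a shorter carbamate, such as the ethyl or isopropyl ester, would do as well as the oxadiazole ring at this nitrogen.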